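Three sulfur-linked side chains on one shared core

The source may hold more compounds than are shown below. What is called first, only, known or untested is meant among the compounds shown, and "the series" means these compounds.

Compound 1, `CN1CCC(c2ccc(Cl)cc2)C(C[S+]([O-])CCO)C1`, gives 12 nM in an assay on isolated protein for inhibition of sodium-dependent dopamine transporter (Rattus norvegicus), read by radioligand binding; on this read-out lower numbers stand for stronger inhibition and higher numbers for weaker inhibition.
Compound 2, `CC(=O)OCCSCC1CN(C)CCC1c1ccc(Cl)cc1`, gives 35 nM in this assay.
Compound 3, `CN1CCC(c2ccc(Cl)cc2)C(C[S+]([O-])CC(=O)NO)C1`, gives 55 nM in this assay.

Compound 3 carries the highest number of the three: from compound 2 it lies a 1.6-fold higher number from compound 2 to compound 3 (0.20 log units; within the scatter), and from compound 1 it lies a 4.6-fold higher number from compound 1 to compound 3 (0.66 log units; beyond the scatter). The unmeasured compound 4, `Cc1noc(C[S+]([O-])CC2CN(C)CCC2c2ccc(Cl)cc2)n1`, differs from compound 3 by 3-methyl-1,2,4-oxadiazol-5-yl in place of hydroxycarbamoyl on a saturated chain carbon bound to a sulfur. For the measured compounds named here, the step that bears most directly on this is the one from compound 1 to compound 3, a 4.6-fold higher number from compound 1 to compound 3 (0.66 log units; beyond the scatter), since it alters the same saturated chain carbon bound to a sulfur; the steps of a 2.9-fold higher number from compound 1 to compound 2 (0.46 log units; beyond the scatter) and a 1.6-fold higher number from compound 2 to compound 3 (0.20 log units; within the scatter) show that the whole side chain can be exchanged with only modest movement. Going by the values given here, no measured pair places an aromatic ring at this position, so the direction is uncertain. A small shift toward the lower number of compound 1 is expected, and the expected step is a 1.4-fold lower number from compound 3 to compound 4 (0.14 log units; within the scatter). Compound 4 is therefore estimated at 40 nM, with a range from 12 nM to 130 nM.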

Compound 4, inhibition constant: 1650 nM
For compound 4 the middle estimate is 41-fold (1.62 log units) below the measured one; the whole stated range lies below it.
By their numbers in this assay, from the lowest: compound 1; then compounds 2 and 3 (each within the scatter of the next); then compound 4.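

At this saturated chain carbon bound to a sulfur, the earlier exchanges had moved the number only modestly, whereas 3-methyl-1,2,4-oxadiazol-5-yl in place of hydroxycarbamoyl gives a 30-fold higher number from compound 3 to compound 4 (1.48 log units; beyond the scatter), so the position does not tolerate every group placed on it. Measured against hydroxymethyl, the same change gives a 140-fold higher number from compound 1 to compound 4 (2.14 log units; beyond the scatter), which shows that the first aromatic ring seen here goes with a large loss of binding in this assay and not with the small shift seen among the open-chain groups. Nothing in the available information accounts for this loss.

With only one ring-bearing group shown, the compounds leave open whether the ring itself or its methyl goes with the higher number. An unsubstituted 1,2,4-oxadiazol-5-yl, a phenyl ring or a carboxylic acid at this place could begin to separate these readings.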